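Fluoro in place of bromo: a small step expected

A few compounds are considered here, and "the series" means these few. Any claim that something is new, unique, unknown or untested is made for them only; others in the source may bear on it.

In a functional assay on SMMC-7721 cells (Homo sapiens) for antiproliferative activity, read by MTT assay, with a stated time of 72 h (a lower number here means a stronger inhibitor, a higher number a weaker inhibitor), compound 1 `C/C(=N\NC(=O)c1cccc(S(=O)(=O)N2CCOCC2)c1)c1cccc(N)c1` gives > 100000 nM, which is a limit of the assay and not a number. Compound 2 `C/C(=N\NC(=O)c1cccc(S(=O)(=O)N2CCOCC2)c1)c1ccccc1O` gives 1370 nM. Compound 3 `C/C(=N\NC(=O)c1cccc(S(=O)(=O)N2CCOCC2)c1)c1cc(Br)ccc1O` gives 2410 nM, a value within the usual scatter of compound 2. Compound 4 `C/C(=N\NC(=O)c1cccc(S(=O)(=O)N2CCOCC2)c1)c1cc(F)ccc1O` differs from compound 3 in one place: fluoro in place of bromo on an aromatic carbon. This puts fluoro in place of bromo on an aromatic carbon, para to a hydroxy group.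

The large measured steps, an at least 72-fold lower number from compound 1 to compound 2 (1.86 log units; beyond the scatter) and an at least 41-fold lower number from compound 1 to compound 3 (1.61 log units; beyond the scatter), exchange the whole 3-aminophenyl group, so they say little about this single swap. The closest guide is a 1.8-fold higher number from compound 2 to compound 3 (0.25 log units; within the scatter), which puts bromo in place of hydrogen at the same spot and stays within the scatter. A similarly small change, with no firm direction, is therefore expected in this assay. The estimated move is a 1.2-fold lower number from compound 3 to compound 4 (0.08 log units; within the scatter), which is expected to stay within the scatter. For compound 4 the expected value is 2000 nM, with an estimated range from 800 nM to 5000 nM.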

Compound 4, half-maximal inhibitory concentration: 1150 nM
Compound 4: the middle estimate sits 1.7-fold (0.24 log units) above what was measured; the measured number falls inside the stated range.
By their numbers in this assay, from the lowest: compounds 4, 2 and 3 (each within the scatter of the next, the first and the last beyond it). At a limit, above all of these: compound 1.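

In this assay, the two halogens at this spot can now be told apart, though only modestly: fluoro in place of bromo gives a 2.1-fold lower number from compound 3 to compound 4 (0.32 log units; beyond the scatter), while fluoro in place of hydrogen gives a 1.2-fold lower number from compound 2 to compound 4 (0.08 log units; within the scatter), so fluoro does not separate from hydrogen here. The 5-fluoro-2-hydroxyphenyl group also shows a large difference from the 3-aminophenyl group, with an at least 86-fold lower number from compound 1 to compound 4 (1.93 log units; beyond the scatter). Compound 1 marks a limit and not a number: the limit of > 100000 nM in this assay, at which 1 of the 4 values shown sits.

As far as these compounds go, it remains open whether a group other than a halogen at this spot, such as an amine, a methoxy group or a carboxylic acid, would stay close to hydrogen. From the compounds shown here alone, it is also open where chloro would fall relative to fluoro and bromo.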